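This account rests on a few compounds, and the source may have more. Where it says the series, first, only, none or still open, it means among the compounds named here.

In an ADME assay on Vero cells (Chlorocebus sabaeus) for cytotoxicity, with a stated time of 72 h (on this read-out lower numbers stand for stronger inhibition and higher numbers for weaker inhibition), compound 3, with the structure `O=[N+]([O-])c1cn2c(n1)OC[C@@H](OCc1ccc(-c3ccc(OC(F)(F)F)cc3)cc1F)C2`, gives > 128000 nM, which is a limit of the assay rather than a measured number. Compound 1, `O=[N+]([O-])c1cn2c(n1)OC[C@@H](OCc1ccc(-c3ccc(OC(F)(F)F)cc3)cc1)C2`, gives > 128000 nM, again a limit. Compound 2, `O=[N+]([O-])c1cn2c(n1)OC[C@@H](OCc1ccc(-c3ccc(OC(F)(F)F)cc3)cc1Cl)C2`, gives > 128000 nM, also a limit. All three values sit at the limit of > 128000 nM in this assay, at which 3 of the 3 values shown sit, so the three steps among them, a step that the two limits leave unreadable from compound 1 to compound 2, a step that the two limits leave unreadable from compound 1 to compound 3 and a step that the two limits leave unreadable from compound 2 to compound 3, cannot be read in size. Compound 4, `N#Cc1cc(-c2ccc(OC(F)(F)F)cc2)ccc1CO[C@@H]1COc2nc([N+](=O)[O-])cn2C1`, differs from compound 3 by cyano in place of fluoro on an aromatic carbon. Among the measured compounds shown here, since none of the measured steps has a readable size, no step beyond the scatter is expected here, and the expected step is a step that the limit leaves unreadable from compound 3 to compound 4. Compound 4 is therefore estimated at 200000 nM, with a range from 64000 nM to 640000 nM, and will most likely again be reported only as a limit.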

Compound 4, half-maximal inhibitory concentration: > 128000 nM
Compound 4: no number, only a limit; the forecaster's own chance of this, stated with the estimate: 85%; the middle value lies beyond the limit too.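

Compound 4, like compounds 1, 2 and 3, gives only a limit and not a number, so none of the steps to compound 4 can be read in size: the limit of > 128000 nM in this assay, at which 4 of the 4 values shown sit. The compounds shown leave open at what concentration these four would inhibit the cells, and whether hydrogen, chloro, fluoro or cyano makes any difference to that.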